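Benzoyl in place of methoxycarbonyl: working notes

This account rests on a few compounds, and the source may have more. Where it says the series, first, only, none or still open, it means among the compounds named here.

- Compound 1 `COC(=O)c1cc2c(F)c(F)c(-n3ccnc3)c(F)c2s1`: > 100000 nM (a limit)
- Compound 2 `COC(=O)c1cc2c(F)c(F)c(Oc3ccccc3Br)c(F)c2s1`: > 25000 nM (a limit)
- Compound 3 `COC(=O)CSc1c(F)c(F)c2cc(C(=O)OC)sc2c1F`: > 25000 nM (a limit)

In an ADME assay on MCF7 cells (Homo sapiens) for inhibition (a higher number here means a weaker inhibitor, a lower number a stronger inhibitor), compound 1 gives only a limit, > 100000 nM, and no number. Among the measured compounds shown here, the values of compound 2 and compound 3 are limits as well, so no measured compound has a readable potency.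

Compound 4 `O=C(c1ccccc1)c1cc2c(F)c(F)c(-n3ccnc3)c(F)c2s1` differs from compound 1 in one place: phenyl in place of methoxy on a carbonyl carbon.

Three measured steps exist: a step that the two limits leave unreadable from compound 1 to compound 2, a step that the two limits leave unreadable from compound 1 to compound 3 and a step that the two limits leave unreadable from compound 2 to compound 3. Each exchanges a group on an aromatic carbon and leaves the methoxy on the carbonyl carbon untouched. None therefore gives a size or direction for this change.

With only limits to go on, compound 4 is expected to remain a weak inhibitor in this assay, quite possibly also reported as a limit. The expected step, loosely held, is an at least 2.0-fold lower number from compound 1 to compound 4 (0.30 log units; that floor lies within the scatter). For compound 4 the estimated value is 50000 nM, with an expected range of 10000 nM to 150000 nM.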

Compound 4, half-maximal inhibitory concentration: > 60000 nM
Compound 4 gave a limit, no number; the forecaster's own chance of this, stated with the estimate: 60%; middle value at least 1.2-fold (0.07 log units) away from the limit.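

In this assay compound 4 gives > 60000 nM, which is a limit. Compound 1 is also a limit, so no step can be read from compound 1 to compound 4. The compounds shown leave open whether benzoyl in place of methoxycarbonyl shifts the read-out, and in which direction.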